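The compounds below may be only part of what the source reports. "The series", "measured", "known", "first", "only" and "open" are said of these compounds alone.

In an ADME assay on microsomes from liver (Rattus norvegicus) for metabolic stability, with a stated time of 10 min, tested at 0.5 uM (on this read-out lower numbers stand for a less stable compound and higher numbers for a more stable compound), three compounds have been measured so far. Compound 3 `Cn1cc(-c2ccc(C(F)(F)F)cc2)c2ccc(C(=O)NS(C)(=O)=O)cc21` gives 74%. Compound 1 `Cn1cc(-c2ccc(C(F)(F)F)cc2)c2ccc(C(=O)NS(=O)(=O)C3CC3)cc21` differs from compound 3 only by cyclopropyl in place of methyl on a sulfonyl sulfur, and in this assay compound 1 gives 92%, which is a number 18 percentage points higher from compound 3 to compound 1 (beyond the scatter). Compound 2 `CC(C)COc1ccc(-c2cn(C)c3cc(C(=O)NS(C)(=O)=O)c(F)cc23)cn1` is built on a different core; the difference between the two cores is not broken down here. In this assay compound 2 gives 98%, a number that lies within the usual scatter of the number for compound 1 and beyond the scatter from the number for compound 3.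

Compound 4 `CC(C)COc1ccc(-c2cn(C)c3cc(C(=O)NS(=O)(=O)C4CC4)c(F)cc23)cn1` has not yet been measured. It is related to compound 2 by cyclopropyl in place of methyl on a sulfonyl sulfur. This is the same change, at the same place, that turns compound 3 into compound 1, and among the compounds shown it occurs twice in all. On its own, the earlier step would point to a rise. However, the read-out reports how much of the compound remains, so it cannot go past full recovery, and compound 2 already stands at 98%, near the top of that scale, leaving almost no room. The step from the measured compound to the new one is therefore expected to be much smaller than the earlier one, at about a number 1 percentage points higher from compound 2 to compound 4 (within the scatter). Compound 4 is estimated to give roughly 99% in this assay, most likely between 94% and 100%.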

Compound 4, percent of the compound remaining: 78%
Compound 4: middle estimate off by 21 percentage points, on the high side, outside the stated range (below it).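

The new step runs the opposite way to the earlier one: a number 20 percentage points lower from compound 2 to compound 4 (beyond the scatter). In this assay, the effect of putting cyclopropyl in place of methyl on a sulfonyl sulfur therefore does not carry over from one core to the other, and a result from one core cannot be used as a forecast for the other: the same change on two cores in this assay, a number 18 percentage points higher (beyond the scatter) from compound 3 to compound 1 and a number 20 percentage points lower (beyond the scatter) from compound 2 to compound 4, 38 percentage points apart, beyond the scatter of two such steps. This does not show why the two cores respond differently, or that the change always raises the number on one core and lowers it on the other, since each direction rests on a single pair of compounds and the difference between the cores is not broken down.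

The compounds shown leave open which part of the cores decides the direction of the step, as no compound here has a core that lies partway between the two. They also leave open how other groups on the sulfonyl sulfur would behave on each core, such as an ethyl group, a longer chain or an amine, and whether any of these would follow the pattern of compound 1 or that of compound 4.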